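A Third Side-Chain Variant on a Shared Core

The compounds below may be only part of what the source reports. "The series", "measured", "known", "first", "only" and "open" are said of these compounds alone.

Compound 1 `CNS(=O)(=O)NC[C@@H]1CCCc2cc(S(=O)(=O)c3cccc(F)c3)ccc21`: 1 nM
Compound 2 `CN(CC(N)=O)C[C@@H]1CCCc2cc(S(=O)(=O)c3cccc(F)c3)ccc21`: 1.26 nM

In an assay on isolated protein for displacement of a labelled ligand from 5-hydroxytryptamine receptor 6 (Homo sapiens) (a higher number here means a weaker inhibitor, a lower number a stronger inhibitor), compound 1 gives 1 nM, while compound 2 gives 1.26 nM. Compound 2 has the higher of the two numbers, yet the step of a 1.3-fold higher number from compound 1 to compound 2 (0.10 log units; within the scatter) lies within the scatter, so the two compounds cannot be ordered. Compound 3 `COC(=O)NC[C@@H]1CCCc2cc(S(=O)(=O)c3cccc(F)c3)ccc21` differs from compound 2 by (methoxycarbonyl)amino in place of (carbamoylmethyl)(methyl)amino on a saturated chain carbon bound to a saturated ring carbon. Among the compounds with values here, the only measured step, a 1.3-fold higher number from compound 1 to compound 2 (0.10 log units; within the scatter), sits at the same place and was flat; the entering group itself is untested. The author therefore expects little movement. For compound 3 the estimate is 1.6 nM, between 0.5 nM and 5 nM, an expected step of a 1.3-fold higher number from compound 2 to compound 3 (0.10 log units; within the scatter).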

Compound 3, inhibition constant: 1.59 nM
Compound 3: middle estimate off by 1.0-fold (0.00 log units), on the high side, within the range that was stated.
By their numbers in this assay, from the lowest: compounds 1, 2 and 3 (each within the scatter of the next).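

In this assay, (methoxycarbonyl)amino in place of (carbamoylmethyl)(methyl)amino on a saturated chain carbon bound to a saturated ring carbon gives no readable shift (a 1.3-fold higher number from compound 2 to compound 3 (0.10 log units; within the scatter)). Methoxycarbonyl in place of methylsulfamoyl on the amine nitrogen is equally unresolved (a 1.6-fold higher number from compound 1 to compound 3 (0.20 log units; within the scatter)), so this place has now carried three different groups with all steps within the scatter. Nothing available explains this flatness. From the compounds shown here alone, whether a free primary amine, a carboxylic acid or a longer chain at this place would also stay within the scatter remains open.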